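The compounds below may be only part of what the source reports. "The series", "measured", "known", "first", "only" and "open" are said of these compounds alone.

Measured in a functional assay on MCF7 cells (Homo sapiens) for cytotoxicity, read by sulforhodamine B assay; a higher number here means that more compound is needed for the effect, a lower number that less compound is needed:
- compound 1 `C=C1CC[C@@H]2[C@](C)(CO[Si](C)(C)C(C)(C)C)[C@H](OC(C)=O)CC[C@@]2(C)[C@@H]1C/C=C1/C(=O)OC[C@H]1OC(C)=O`: 2.84 uM
- compound 2 `C=C1CC[C@@H]2[C@](C)(CO[Si](C)(C)C(C)(C)C)[C@H](O)CC[C@@]2(C)[C@@H]1C/C=C1/C(=O)OC[C@H]1OC(C)=O`: 10.4 uM
- compound 3 `C=C1CC[C@@H]2[C@](C)(CO[Si](C)(C)C(C)(C)C)[C@H](O)CC[C@@]2(C)[C@@H]1C/C=C1/C(=O)OC[C@H]1O`: 47 uM

Compound 2 stands in the middle of these three numbers, and its gaps to both neighbours are larger than the usual scatter of repeated measurements. Compound 4 `C=C1CC[C@@H]2[C@](C)(COC(C)=O)[C@H](O)CC[C@@]2(C)[C@@H]1C/C=C1/C(=O)OC[C@H]1OC(C)=O` is built from compound 2 by one change on an oxygen on a saturated carbon, where acetyl replaces the silicon-containing group: a group of 3 heavy atoms (2 carbon, 1 oxygen; no ring) in place of a group of 7 heavy atoms (6 carbon, 1 silicon; no ring), on an oxygen on a saturated carbon.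

Within the data shown here, no measured step shows this exact swap, since compound 1, compound 2 and compound 3 all keep the silicon-containing group. The nearest guides are two steps in which hydrogen replaces acetyl on an oxygen on a saturated carbon. The first is a 3.7-fold higher number from compound 1 to compound 2 (0.56 log units; beyond the scatter), and the second is a 4.5-fold higher number from compound 2 to compound 3 (0.66 log units; beyond the scatter). Each puts a smaller group in place of a larger one, and each raises the number by a modest amount. The swap in compound 4 also puts a smaller group in place of a larger one, so the same direction seems the best guess, though only a weak one. The expected step is a 2.4-fold higher number from compound 2 to compound 4 (0.38 log units; beyond the scatter), again modest and toward a higher number. In this assay, the estimate for compound 4 is 25 uM, with an expected range from 8 uM to 75 uM.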

Compound 4, concentration for half-maximal effect: 18.5 uM
Compound 4: the middle estimate sits 1.4-fold (0.13 log units) above what was measured; low and high end bracket the measured number.
By their numbers in this assay, from the lowest: compound 1; then compounds 2 and 4 (each within the scatter of the next); then compound 3.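

Until now, every compound carried the silicon-containing group, so nothing showed whether the number in this assay depended on it. The swap to acetyl on this oxygen gives a 1.8-fold higher number from compound 2 to compound 4 (0.25 log units; within the scatter), so the large silicon-containing group of 7 heavy atoms can give way to a group of 3 heavy atoms with no change that can be told apart from the scatter, unlike the two earlier steps from acetyl to hydrogen, which were beyond it. Nothing available here explains why this swap behaves as it does. 

The compounds shown leave open how this oxygen would respond to groups of other kinds, such as a benzoyl group, a simple methyl group or a longer chain ending in an amine, so two groups at one position cannot show how far this tolerance extends. As far as these compounds go, it also remains open whether the same swap would leave the number just as steady on compound 1 or compound 3, whose other oxygens carry different groups from those on compound 2.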